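Trading Isopropylsulfonyl for Propanoyl on the Ring Nitrogen

This account rests on a few compounds, and the source may have more. Where it says the series, first, only, none or still open, it means among the compounds named here.

Compound 1 `CC(C)S(=O)(=O)N1CCCC(NS(=O)(=O)c2ccc(F)cc2)C1` and compound 2 `O=S(=O)(NCC1CCN(S(=O)(=O)c2ccc(F)cc2)CC1)c1ccc(F)cc1` were both tested in a functional assay on the whole organism with Mus musculus as the target, with a stated time of 30 min; on this read-out lower numbers stand for an effect already at smaller amounts and higher numbers for an effect only at larger amounts of compound. In this assay compound 1 gives 10 mg/kg, the highest of the two numbers, while compound 2 gives 1 mg/kg, a gap beyond the usual scatter. Compound 3 `CCC(=O)N1CCCC(NS(=O)(=O)c2ccc(F)cc2)C1` has not yet been measured; it differs from compound 1 in one place: propanoyl in place of isopropylsulfonyl on an amine nitrogen in a ring. Within the data shown here, no measured pair shows this same change, so no direct step is available to lean on. A modest shift toward a higher number is expected, with a 1.5-fold higher number from compound 1 to compound 3 (0.18 log units; within the scatter) as the estimated step. Compound 3 is therefore expected to give 15 mg/kg, within a range from 5 mg/kg to 50 mg/kg.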

Compound 3, minimum effective dose: 10 mg/kg
Beside the measured number, compound 3's estimate is 1.5-fold (0.18 log units) above it; measured number inside the range.
By their numbers in this assay, from the lowest: compound 2; then compounds 1 and 3 (each within the scatter of the next).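

In this assay, putting propanoyl in place of isopropylsulfonyl on the ring nitrogen gives no change at the digits printed from compound 1 to compound 3 (within the scatter). At this position, then, the sulfonyl link is not needed to keep the dose at the level of compound 1, and the smaller carbonyl-bearing propanoyl group serves just as well. No measurement is available that explains why the two groups match.

On these data alone, whether an amine, a simple alkyl chain or a longer acyl chain on this nitrogen would match them remains open. So does whether the same swap would behave alike on the core of compound 2.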